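Shifting a hydroxy group on a shared three-aryl core

The source may report more compounds than this note shows. Statements on the series, on what has been measured and on what is new or still open speak of the compounds shown alone.

compound 1 `Oc1ccc(-c2cc(-c3ccccc3F)cc(-c3ccccc3O)n2)cc1`: > 50000 nM
compound 2 `Oc1cccc(-c2cc(-c3ccc(C(F)(F)F)cc3)cc(-c3ccccc3O)n2)c1`: > 50000 nM
compound 3 `Oc1ccc(-c2cc(-c3ccc(C(F)(F)F)cc3)cc(-c3ccccc3O)n2)cc1`: > 50000 nM

In a functional assay on HCT-15 cells (Homo sapiens) for inhibition (a lower number here means a stronger inhibitor, a higher number a weaker inhibitor), compound 1 gives > 50000 nM, a limit of the assay and not a number. Compound 2 likewise gives > 50000 nM, again a limit. Compound 3 gives > 50000 nM, also a limit, so compound 3 sits at the limit of > 50000 nM in this assay, at which 3 of the 3 values shown sit, together with the other two. The steps a step that the two limits leave unreadable from compound 1 to compound 3 and a step that the two limits leave unreadable from compound 2 to compound 3 therefore carry no readable size.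

Compound 4 `Oc1ccc(-c2cc(-c3ccc(C(F)(F)F)cc3)cc(-c3ccc(O)cc3)n2)cc1` differs from compound 3 by 4-hydroxyphenyl in place of 2-hydroxyphenyl on an aromatic carbon. Going by the values given here, no measured step gives a readable size for this kind of change, and all values so far sit at the limit. Compound 4 is therefore expected to remain at the limit, with an estimated 60000 nM and a range from 20000 nM to 200000 nM. The expected step that the limit leaves unreadable from compound 3 to compound 4 is accordingly not read as a change beyond the scatter.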

Compound 4, half-maximal inhibitory concentration: > 50000 nM
Compound 4 was reported as a limit (the forecaster's own chance of this, stated with the estimate: 85%); the middle value does not contradict the limit.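

Compound 3 and compound 4 both stand as limits in this assay, so the change from 2-hydroxyphenyl to 4-hydroxyphenyl gives no readable step. The compounds shown leave open how any of these changes alters inhibition, with every value at one limit: the limit of > 50000 nM in this assay, at which 4 of the 4 values shown sit.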